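Swapping one group on an amide-type nitrogen

A few compounds are considered here, and "the series" means these few. Any claim that something is new, unique, unknown or untested is made for them only; others in the source may bear on it.

Measured in a functional assay on MCF7 cells (Homo sapiens) for antiproliferative activity, read by MTT assay; a lower number here means a stronger inhibitor, a higher number a weaker inhibitor:
- compound 1 `COc1cc2c(Oc3ccc(NC(=O)Nc4ccc(C(F)(F)F)cc4Cl)cc3)ccnc2cc1OCCCCCCC(=O)NO` gives 500 nM
- compound 2 `COc1cc2c(Oc3ccc(NC(=O)NC4CCCCC4)cc3)ccnc2cc1OCCCCCCC(=O)NO` gives 600 nM
- compound 3 `COc1ccccc1NC(=O)Nc1ccc(Oc2ccnc3cc(OCCCCCCC(=O)NO)c(OC)cc23)cc1` gives 6280 nM

Compound 3 has the highest number of the three, so it is the weakest inhibitor here. Compound 4 `COc1cc2c(Oc3ccc(NC(=O)N/N=C/c4ccccc4)cc3)ccnc2cc1OCCCCCCC(=O)NO` differs from compound 3 by one change, (a group of 8 heavy atoms (7 carbon, 1 nitrogen; one six-membered aromatic ring of carbon only) in place of a group of 8 heavy atoms (7 carbon, 1 oxygen; one six-membered aromatic ring of carbon only), on an amide-type nitrogen), and the rest of the structure stays the same.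

Swaps at this same nitrogen gave a 13-fold higher number from compound 1 to compound 3 (1.10 log units; beyond the scatter) and a 10-fold higher number from compound 2 to compound 3 (1.02 log units; beyond the scatter), both large, although a 1.2-fold higher number from compound 1 to compound 2 (0.08 log units; within the scatter) shows that a swap can also change little. Among the compounds with values here, none of the measured compounds carries the entering group, so the direction remains uncertain.

Compound 3 stands at the top of the measured numbers with 6280 nM, so a moderate move downward is expected. The expected change in this assay is a 4.2-fold lower number from compound 3 to compound 4 (0.62 log units; beyond the scatter), which is only an estimate. Compound 4 is estimated at 1500 nM (expected range 400 nM to 6000 nM).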

Compound 4, half-maximal inhibitory concentration: 610 nM
Beside the measured number, compound 4's estimate is 2.5-fold (0.39 log units) above it; the measured number falls inside the stated range.
By their numbers in this assay, from the lowest: compounds 1, 2 and 4 (each within the scatter of the next); then compound 3.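

At this amide-type nitrogen in this assay, the entering group, with its double bond outside the aromatic ring, gives a 10-fold lower number from compound 3 to compound 4 (1.01 log units; beyond the scatter). It also reads level with both other groups, with a 1.0-fold higher number from compound 2 to compound 4 (0.01 log units; within the scatter) and a 1.2-fold higher number from compound 1 to compound 4 (0.09 log units; within the scatter), so three quite different groups now share one level and only 2-methoxyphenyl stands apart. Nothing available explains why 2-methoxyphenyl differs from the other groups.

As far as these compounds go, whether a plain phenyl or a benzyl group on this nitrogen would read like compound 3 or like the other three remains open.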